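This account rests on a few compounds, and the source may have more. Where it says the series, first, only, none or still open, it means among the compounds named here.

Measured compounds:
Compound 1 `FC(F)(F)c1ccc(NC2=NCCC3(CCCCC3)S2)cc1` gives 77600 nM in a functional assay on a subcellular fraction from brain (Rattus norvegicus) for inhibition, read by scintillation counting, with a stated time of 5 min; on this read-out lower numbers stand for stronger inhibition and higher numbers for weaker inhibition.
Compound 2 `CC(=O)c1ccc(NC2=NCCC3(CCCCC3)S2)cc1` gives 81300 nM in this assay.

Going by the values given here, compound 2 holds the highest of the two numbers measured so far, but its nearest neighbour is compound 1, and the step of a 1.0-fold higher number from compound 1 to compound 2 (0.02 log units; within the scatter) sits within the scatter, so the two cannot be told apart on this read-out. Compound 3 `CCc1ccc(NC2=NCCC3(CCCCC3)S2)cc1` has not yet been measured. It differs from compound 2 in one place: ethyl in place of acetyl on an aromatic carbon, on an aromatic carbon of a six-membered aromatic ring of carbon only, para to a large group. Among the compounds with values here, no measured step swaps an acetyl for an ethyl, so the only guide is the step of a 1.0-fold higher number from compound 1 to compound 2 (0.02 log units; within the scatter), where exchanging one group at this same aromatic carbon for another left the number essentially unchanged. On that basis the change to compound 3 is expected to produce no step beyond the scatter in this assay. The estimate for compound 3 is therefore 80000 nM, with a range from 30000 nM to 200000 nM, meaning an expected step of a 1.0-fold lower number from compound 2 to compound 3 (0.01 log units; within the scatter).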

Compound 3, half-maximal inhibitory concentration: 11700 nM
The estimate for compound 3 lay 6.8-fold (0.83 log units) above the measured number; measured number outside the range, below it.
By their numbers in this assay, from the lowest: compound 3; then compounds 1 and 2 (each within the scatter of the next).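

In this assay, the aromatic carbon para to a large group had looked indifferent to its substituent, since a 1.0-fold higher number from compound 1 to compound 2 (0.02 log units; within the scatter), but ethyl shows that this position does respond to the group it carries, with a 6.9-fold lower number from compound 2 to compound 3 (0.84 log units; beyond the scatter) and a 6.6-fold lower number from compound 1 to compound 3 (0.82 log units; beyond the scatter). The change from acetyl to ethyl removes a carbonyl and a hydrogen-bond acceptor, yet the loss of the carbonyl cannot alone mark the difference, as compound 1 carries trifluoromethyl, which has no carbonyl, and still stands within the scatter of compound 2. Nothing available here bears on why ethyl separates from the other two groups.

With only three groups at this carbon, the compounds shown do not tell whether the lower number belongs to ethyl in particular or would extend to plain carbon chains in general, such as methyl or a longer propyl chain. They also leave open how an amine, a hydroxyl or a carboxylic acid at the same carbon would read, and whether the same exchange would give a step of this size on another core.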